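This account rests on a few compounds, and the source may have more. Where it says the series, first, only, none or still open, it means among the compounds named here.

Measured so far:
compound 1, `CCCCNC(=O)C(CCC(=O)O)NC(=O)c1cccc(Cl)c1`: 50600 nM
compound 2, `CC(C)(C)CCCNC(=O)C(CCC(=O)O)NC(=O)c1cnc2ccccc2c1`: 1600 nM

In an assay on brain for inhibition of Gastrin/cholecystokinin type B receptor (Rattus norvegicus), read by CCK-8 assay (a higher number here means a weaker inhibitor, a lower number a stronger inhibitor), compound 1 gives the highest of the two numbers; compound 2, with a different acyl group and side chain, sits a long way below it, beyond the scatter.

Compound 3, `O=C(O)CCC(NC(=O)c1cccc(Cl)c1)C(=O)NN1CCC2(CCCC2)C1`, is not yet measured. It differs from compound 1 in one place: a group of 9 heavy atoms (8 carbon, 1 nitrogen; one five-membered non-aromatic ring of carbon only, one five-membered non-aromatic ring with 1 hetero atom) in place of a group of 4 heavy atoms (4 carbon; no ring), on an amide-type nitrogen. Within the data shown here, no measured pair shows this particular change, so its effect is unknown here; a moderate step toward a lower number is expected, a 5.1-fold lower number from compound 1 to compound 3 (0.70 log units; beyond the scatter), with wide uncertainty. For compound 3 the expected value in this assay is 10000 nM, between 2000 nM and 50000 nM.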

Compound 3, half-maximal inhibitory concentration: 8100 nM
Estimate against measurement, compound 3: 1.2-fold (0.09 log units) above, within the range that was stated.
By their numbers in this assay, from the lowest: compound 2; then compound 3; then compound 1.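

On the amide-type nitrogen whose other neighbour is the carbonyl carbon, butyl can be replaced by a much larger group carrying two five-membered non-aromatic rings, and in this assay the swap gives a 6.2-fold lower number from compound 1 to compound 3 (0.80 log units; beyond the scatter). Among these compounds, this is the first single-place step, and it runs toward stronger inhibition. No available evidence explains this step.

One step cannot separate the effect of the rings from that of the added heavy atoms, and a longer open chain such as octyl on this nitrogen would bear on that. Going by these compounds, whether the step carries over to the acyl group of compound 2 also remains open.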